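Cyano in place of ethoxycarbonyl, starting from a limit

The source may report more compounds than this note shows. Statements on the series, on what has been measured and on what is new or still open speak of the compounds shown alone.

Compound 1 `CSc1nc(Cl)c(C(=O)c2ccccc2)s1`: > 100000 nM, a limit of the assay
Compound 2 `CCOC(=O)c1sc(N2CCCC2)nc1Cl`: > 100000 nM, a limit of the assay
Compound 3 `O=C(c1ccccc1)c1sc(N2CCCC2)nc1Cl`: 82000 nM

In a functional assay on U-373MG ATCC cells (Homo sapiens) for cytotoxicity, read by MTT assay, with a stated time of 72 h (a lower number here means a stronger inhibitor, a higher number a weaker inhibitor), compound 2 stands at > 100000 nM, which is a limit and not a number. Compound 4 `N#Cc1sc(N2CCCC2)nc1Cl` differs from it in one group: cyano in place of ethoxycarbonyl on an aromatic carbon. For the measured compounds named here, the one measured change at this place gave an at least 1.2-fold lower number from compound 2 to compound 3 (0.08 log units; that floor lies within the scatter). The other measured step, an at least 1.2-fold lower number from compound 1 to compound 3 (0.08 log units; that floor lies within the scatter), concerns pyrrolidin-1-yl in place of methylsulfanyl, so it bears on this change less directly. Neither step shows a clear gain, so no change beyond the scatter is expected in this assay. The expected step is a number no higher from compound 2 to compound 4 (the limit leaves the size open). For compound 4 the estimate is 100000 nM, with an expected range from 40000 nM to 200000 nM.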

Compound 4, half-maximal inhibitory concentration: > 100000 nM
Compound 4: only a limit was reported (the forecaster's own chance of this, stated with the estimate: 60%); the middle value lies on the limit itself.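

For the compounds shown here, compound 2 and compound 4 both stand at a limit, not a number, in this assay; no step between them can be read. The compounds shown leave open whether cyano in place of ethoxycarbonyl changes the number at all.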